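The source may hold more compounds than are shown below. What is called first, only, known or untested is meant among the compounds shown, and "the series" means these compounds.

Measured compounds in an assay on THP-1 cells for displacement of a labelled ligand from C-C chemokine receptor type 1 (Homo sapiens); on this read-out lower numbers stand for stronger inhibition and higher numbers for weaker inhibition:
- compound 1 `CC(C)[C@@H](NC(=O)c1nc2ccccc2s1)C(=O)N1CCC(c2ccc(Cl)cc2)CC1`: 18 nM
- compound 2 `CC(C)[C@@H](NC(=O)c1cccc(F)c1)C(=O)N1CCC(c2ccc(Cl)cc2)CC1`: 24 nM
- compound 3 `CC(C)CC(=O)N[C@@H](C(=O)N1CCC(c2ccc(Cl)cc2)CC1)C(C)C`: 32 nM

All three share the same core and differ only in the group on the carbonyl carbon attached to the amide-type nitrogen. Compound 3 gives the highest number of the three, but its distance to compound 2, a 1.3-fold higher number from compound 2 to compound 3 (0.12 log units; within the scatter), and to compound 1, a 1.8-fold higher number from compound 1 to compound 3 (0.25 log units; within the scatter), both lie within the scatter, so no order among the three can be read from the numbers.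

Compound 4 `CC(C)[C@@H](NC(=O)c1cc2ccccc2s1)C(=O)N1CCC(c2ccc(Cl)cc2)CC1` has not yet been measured. It differs from compound 3 as follows: 1-benzothiophen-2-yl in place of isobutyl on a carbonyl carbon. The closest measured step is a 1.8-fold higher number from compound 1 to compound 3 (0.25 log units; within the scatter), where a bicyclic group on the same carbonyl carbon was exchanged for isobutyl; the step of a 1.3-fold higher number from compound 2 to compound 3 (0.12 log units; within the scatter) shows the same small movement. Both lie within the scatter, so for compound 4 a step of at most that size back towards the number of compound 1 is expected, a 1.6-fold lower number from compound 3 to compound 4 (0.20 log units; within the scatter), and nothing clearly beyond the scatter. The estimate for compound 4 in this assay is 20 nM, with a range from 8 nM to 50 nM.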

Compound 4, half-maximal inhibitory concentration: 58 nM
Compound 4: middle estimate off by 2.9-fold (0.46 log units), on the low side, and the stated range ends below it.
By their numbers in this assay, from the lowest: compounds 1, 2, 3 and 4 (each within the scatter of the next, the first and the last beyond it).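

In this assay this place, on a carbonyl carbon whose other neighbour is the amide-type nitrogen, now gives steps beyond the scatter, all modest (a 2.4-fold higher number from compound 2 to compound 4 (0.38 log units; beyond the scatter) and a 3.2-fold higher number from compound 1 to compound 4 (0.51 log units; beyond the scatter)), whereas every step among compound 1, compound 2 and compound 3 stayed within it. Two aromatic rings on the carbonyl carbon do not by themselves set the number, since the exchange of 1,3-benzothiazol-2-yl for 1-benzothiophen-2-yl carries the largest step in the set, while the exchange of isobutyl for 1-benzothiophen-2-yl (a 1.8-fold higher number from compound 3 to compound 4 (0.26 log units; within the scatter)) cannot be told from the scatter. No measurement at hand accounts for the gap between these two bicyclic groups.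

As far as these compounds go, whether a quinolin-2-yl group in this place would stay with compound 1 or with compound 4 remains open. So does whether an amine, a carboxylic acid or a longer chain here would move the number at all.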